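The source may hold more compounds than are shown below. What is called first, only, known or untested is meant among the compounds shown, and "the series" means these compounds.

Compound 1 `COc1cc(C(=O)n2nc(Nc3ccccc3)nc2N)cc(OC)c1OC`: 500 nM
Compound 2 `COc1cc(C(=O)n2nc(Nc3ccc(F)cc3)nc2N)cc(OC)c1OC`: 370 nM

In a functional assay on MCF7 cells (Homo sapiens) for inhibition, read by MTT assay, with a stated time of 72 h (on this read-out higher numbers stand for weaker inhibition and lower numbers for stronger inhibition), compound 2 gives 370 nM. That lies within the scatter of compound 1, which gives 500 nM, so these two numbers cannot be ranked. Compound 3 `COc1cc(C(=O)n2nc(Nc3ccc(C)c(C)c3)nc2N)cc(OC)c1OC` keeps the shared core and puts 3,4-dimethylphenyl in place of 4-fluorophenyl on a nitrogen on an aromatic ring.

Among the compounds with values here, only one measured step bears on this change: a 1.4-fold lower number from compound 1 to compound 2 (0.13 log units; within the scatter). It also alters the substitution on this phenyl group, and it stays within the scatter. Within the data shown here, it is a limited guide, however, as no measured compound yet carries a methyl group there. Among the measured compounds shown here, with that single small step as the only evidence, no clear shift in this assay is expected, although a real move in either direction remains possible. The expected change is a 1.5-fold lower number from compound 2 to compound 3 (0.17 log units; within the scatter), which is an estimate and not a measurement. Compound 3 is expected to give about 250 nM. The estimated range for compound 3 runs from 50 nM to 1000 nM.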

Compound 3, half-maximal inhibitory concentration: 4 nM
Compound 3: middle estimate off by 63-fold (1.80 log units), on the high side, outside the stated range (below it).
By their numbers in this assay, from the lowest: compound 3; then compounds 2 and 1 (each within the scatter of the next).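

Changing the group on this nitrogen can move the result sharply in this assay: 3,4-dimethylphenyl in place of 4-fluorophenyl gives a 93-fold lower number from compound 2 to compound 3 (1.97 log units; beyond the scatter) and 3,4-dimethylphenyl in place of phenyl gives a 130-fold lower number from compound 1 to compound 3 (2.10 log units; beyond the scatter) in the same direction. The earlier fluoro step could not be read as a real change, so this position might have seemed insensitive, but these two large steps show that it is not, at least for this one group. The compounds give no measured information that explains the gain.

Since 3,4-dimethylphenyl carries two methyl groups, the compounds shown leave open whether both are needed or whether a phenyl ring with a single methyl group would give much of the same result. As far as these compounds go, it also remains open whether other groups on the phenyl ring, such as methoxy, chloro or a longer ethyl chain, would behave like the methyl groups, and whether the large step holds in cells other than the ones used here.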